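The compounds below may be only part of what the source reports. "The series", "measured", "known", "first", "only" and "open" are said of these compounds alone.

Compound 1 `CN(c1ncccc1CNc1nc(Nc2ccccc2)nc2[nH]cc(F)c12)S(C)(=O)=O` gives in a functional assay on SMMC-7721 cells (Homo sapiens) for inhibition, read by MTT assay, with a stated time of 48 h (on this read-out higher numbers stand for weaker inhibition and lower numbers for stronger inhibition), the limit > 100000 nM.
Compound 2 `COc1cc(Nc2nc(NCc3cccnc3N(C)S(C)(=O)=O)c3c(F)c[nH]c3n2)cc(OC)c1OC` gives in this assay the limit > 100000 nM.
Compound 3 `COc1cccc(Nc2nc(NCc3cccnc3N(C)S(C)(=O)=O)c3c(F)c[nH]c3n2)c1C` gives in this assay the limit > 100000 nM.

Compound 3 therefore stands only at a limit of this assay, not at a measured number, and the two other compounds stand at the same limit. The step that the two limits leave unreadable from compound 1 to compound 3 and the step that the two limits leave unreadable from compound 2 to compound 3 cannot be read in size, and the same holds for a step that the two limits leave unreadable from compound 1 to compound 2, because all three values sit at the limit of > 100000 nM in this assay, at which 3 of the 3 values shown sit. Nothing on the measured side distinguishes one phenyl substituent from another.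

Compound 4 `CN(c1ncccc1CNc1nc(Nc2cccc(CN)c2)nc2[nH]cc(F)c12)S(C)(=O)=O` carries the change (3-(aminomethyl)phenyl in place of 3-methoxy-2-methylphenyl on a nitrogen on an aromatic ring). Going by the values given here, none of the measured steps gives a readable size, so no direction can be taken from them; what the three compounds share is that changing the group on this nitrogen left each of them at the limit. The step that the limit leaves unreadable from compound 3 to compound 4 is therefore expected to be small or not readable, with the result most likely again at the limit rather than a number. Compound 4 is estimated at 120000 nM, within a range from 30000 nM to 500000 nM, in this assay.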

Compound 4, half-maximal inhibitory concentration: > 100000 nM
Compound 4: a limit, no number (the forecaster's own chance of this, stated with the estimate: 75%); the middle value does not contradict the limit.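

In this assay compound 4 gives > 100000 nM and this is a limit, not a number. The steps joining compound 4 to compound 1, compound 2 and compound 3 therefore cannot be read in size, because every value sits at the same limit: the limit of > 100000 nM in this assay, at which 4 of the 4 values shown sit. The compounds shown leave open whether any group on this nitrogen can give a measurable inhibition, and how such groups would rank.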